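The compounds below may be only part of what the source reports. "The series", "measured", "known", "first", "only" and "open" are said of these compounds alone.

Measured in a functional assay on HCT-116 cells (Homo sapiens) for antiproliferative activity, read by MTT assay, with a stated time of 72 h; on this read-out higher numbers stand for weaker inhibition and lower numbers for stronger inhibition:
- Compound 1 `O=C1COc2ccc(-c3cnc(Cl)c(NS(=O)(=O)c4ccc(F)cc4)c3)cc2N1C1CCCCC1`: > 40000 nM
- Compound 2 `COc1ncc(-c2ccc3c(c2)NC(=O)CO3)cc1NS(=O)(=O)c1ccc(F)cc1`: 24900 nM

The value for compound 1 is a limit of this assay and not a number. Among the compounds with values here, that leaves compound 2, at 24900 nM, with the only actual number in this small set, so it has no numerical neighbour against which to be ranked.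

The next compound to be tested is compound 3 `COc1ccc(N2C(=O)COc3ccc(-c4cnc(OC)c(NS(=O)(=O)c5ccc(F)cc5)c4)cc32)cc1`. It keeps the core of compound 2 and changes one place: 4-methoxyphenyl in place of hydrogen on an amide-type nitrogen in a ring. In words, 4-methoxyphenyl stands in place of hydrogen on an amide-type nitrogen in a ring.

Within the data shown here, no measured pair isolates this change, so the expectation is a loose one. Compound 1 gives no number to work from, and compound 2 at 24900 nM leaves ample room toward stronger inhibition. A moderate step in that direction, clearly beyond the scatter, is expected, although a result close to compound 2 would not be surprising.

The estimate amounts to an expected 6.2-fold lower number from compound 2 to compound 3 (0.79 log units; beyond the scatter). For compound 3 the expected value in this assay is 4000 nM, with an estimated range of 400 nM to 30000 nM.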

Compound 3, half-maximal inhibitory concentration: 13400 nM
Compound 3: middle estimate off by 3.4-fold (0.53 log units), on the low side; low and high end bracket the measured number.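

In this assay, setting 4-methoxyphenyl in place of hydrogen on the amide-type nitrogen in the ring gives a 1.9-fold lower number from compound 2 to compound 3 (0.27 log units; within the scatter), so the read-out does not separate the two compounds and this position accepts an added aromatic ring without a measurable loss or gain. Within the data shown here, this is the first pair in the set that differs in one place, and it gives the first direct reading at this nitrogen, whereas compound 1 differs from each of the others in more than one place and so cannot be set against them. Compound 1 remains at a limit of the read-out, which is not a number: the limit of > 40000 nM in this assay, at which 1 of the 3 values shown sits.

Going by these compounds, what remains open is whether anything placed on this nitrogen can move the result beyond the scatter, since a single aromatic group says little about a small methyl, a longer chain ending in an amine, or a carboxylic acid. The 4-methoxyphenyl ring also leaves open how a different group on that ring, such as a nitrile or trifluoromethyl in place of methoxy, would read in this assay.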